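A few compounds are considered here, and "the series" means these few. Any claim that something is new, unique, unknown or untested is made for them only; others in the source may bear on it.

Measured so far:
- compound 1, `Cc1cc(/C=C/C#N)cc(C)c1Oc1nc(Nc2ccc(CN3CCN(S(C)(=O)=O)CC3)cc2)nc2sccc12`: 131000 nM
- compound 2, `Cc1cc(/C=C/C#N)cc(C)c1Oc1nc(Nc2ccc(CN3CCNCC3)cc2)nc2ccsc12`: 3970 nM

Both were run in an ADME assay on MT4 cells (Homo sapiens) for cytotoxicity, read by MTT assay, with a stated time of 5 days; a lower number here means that less compound is tolerated, a higher number that more compound is tolerated. Compound 1 gives 131000 nM and has the highest number of the two; compound 2 with 3970 nM sits far lower, a gap well beyond the scatter. Going by the values given here, no single-change step between the two is recorded, so the pair shows only that the two values lie far apart.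

Compound 3, `Cc1cc(/C=C/C#N)cc(C)c1Oc1nc(Nc2ccc(N3CCN(S(N)(=O)=O)CC3)cc2)nc2sccc12`, is not yet measured in this assay. Compared with compound 1 it carries 4-sulfamoylpiperazin-1-yl in place of (4-(methylsulfonyl)piperazin-1-yl)methyl on an aromatic carbon. The place is an aromatic carbon of a six-membered aromatic ring of carbon only, para to a large group; the group that leaves has no hydrogen-bond donor, the group that enters has one.

Among the compounds with values here, with no measured step of this kind to lean on, the expectation for compound 3 rests on compound 1 at 131000 nM alone. A modest downward step of a 1.6-fold lower number from compound 1 to compound 3 (0.21 log units; within the scatter) is expected, close to the edge of the scatter. Compound 3 is estimated at 80000 nM, with a range from 15000 nM to 250000 nM.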

Compound 3, half-maximal cytotoxic concentration: > 222000 nM
Compound 3 was reported as a limit (the forecaster's own chance of this, stated with the estimate: 25%); middle value at least 2.7-fold (0.44 log units) away from the limit.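

In this assay compound 3 gives > 222000 nM, which is a limit of the assay and not a number. Placing 4-sulfamoylpiperazin-1-yl instead of (4-(methylsulfonyl)piperazin-1-yl)methyl on the aromatic carbon, para to a large group, gives an at least 1.6-fold higher number from compound 1 to compound 3 (0.22 log units; that floor lies within the scatter), so this position accepts the change, including the added hydrogen-bond donor, with no drop in the number in this assay. How far the step extends past its floor cannot be read: the limit of > 222000 nM in this assay, at which 1 of the 3 values shown sits.

On these data alone, this single step replaces the sulfonyl end group and removes the methyl link to the aromatic ring together, so the share of each part in the result stays open. Also open, as far as these compounds go, is how a piperazine carrying an acetyl group or an acetic acid chain in place of the sulfonyl end group would read in this assay.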